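Methoxy step on compound 2

The compounds below may be only part of what the source reports. "The series", "measured", "known", "first", "only" and "open" are said of these compounds alone.

In a functional assay on UO-31 cells (Homo sapiens) for antiproliferative activity, read by sulforhodamine B assay, with a stated time of 72 h (on this read-out higher numbers stand for weaker inhibition and lower numbers for stronger inhibition), compound 1 (`C(=C/c1ccccc1)\C(=N\Nc1nncc2ccccc12)c1ccccc1`) reads 3.9 nM and compound 2 (`S=C(NNc1nncc2ccccc12)Nc1ccccc1`) reads 56 nM under the same conditions. Compound 2 therefore holds the higher number of the two, meaning the weaker inhibition, and the gap lies beyond the scatter. The two compounds differ in more than one place, so their gap gives no measure of a single substitution.

Compound 3 (`COc1ccc(NC(=S)NNc2nncc3ccccc23)cc1`) departs from compound 2 by one change: methoxy in place of hydrogen on an aromatic carbon (methoxy in place of hydrogen on an aromatic carbon, para to a large group). For the measured compounds named here, the series holds no measured precedent for this change, so no firm direction can be assigned. The estimated step of a 1.2-fold lower number from compound 2 to compound 3 (0.09 log units; within the scatter) is expected to stay within the scatter in this assay as the read-out. Compound 3 is estimated at 45 nM with an expected range from 14 nM to 140 nM on this limited evidence.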

Compound 3, half-maximal inhibitory concentration: 47 nM
Compound 3: middle estimate off by 1.0-fold (0.02 log units), on the low side; measured number inside the range.
By their numbers in this assay, from the lowest: compound 1; then compounds 3 and 2 (each within the scatter of the next).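

In this assay, a 1.2-fold lower number from compound 2 to compound 3 (0.08 log units; within the scatter) gives the series its first step that can be read at a single place, and it lies within the scatter. Methoxy in place of hydrogen on an aromatic carbon, para to a large group, therefore leaves the read-out of this pair indistinguishable, so this position accepts the group without a measurable penalty or gain. Nothing on hand bears on why this read-out holds at this position.

Open, from the compounds shown here alone, is whether any other group at the same place, such as an amine, a carboxylic acid, or a longer chain like butoxy, would give a step beyond the scatter. Also open, going by these compounds, is whether methoxy behaves the same way elsewhere on this ring, or on the core of compound 1, where the lower number sits.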